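The source may hold more compounds than are shown below. What is called first, only, known or untested is meant among the compounds shown, and "the series" means these compounds.

Three compounds from this study have been examined in a functional assay on MCF7 cells (Homo sapiens) for cytotoxicity, read by sulforhodamine B assay, with a stated time of 48 h (a lower number here means a stronger inhibitor, a higher number a weaker inhibitor), and a fourth remains to be tested.

Compound 1 `NS(=O)(=O)c1ccc(NNc2ncnc3ccccc23)cc1` gives 1.13 ug/mL in this assay. Compound 2 `N=C(N)NS(=O)(=O)c1ccc(NNc2ncnc3ccccc23)cc1` carries one change on the core of compound 1, namely (a group of 3 heavy atoms (1 carbon, 2 nitrogen; no ring) in place of a hydrogen atom, on a sulfonamide nitrogen). In this assay compound 2 gives 1.65 ug/mL, and the resulting step is a 1.5-fold higher number from compound 1 to compound 2 (0.16 log units; within the scatter), so the two numbers cannot be told apart with confidence.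

Compound 3 `NS(=O)(=O)c1ccc(NNC2=NS(=O)(=O)c3ccccc32)cc1` rests on a different core; the difference between the two cores is not broken down here. In this assay compound 3 gives 3.73 ug/mL, the highest of the three numbers, and its gaps to compound 2 and compound 1 both lie beyond the scatter.

Compound 4 `N=C(N)NS(=O)(=O)c1ccc(NNC2=NS(=O)(=O)c3ccccc32)cc1` has not yet been measured. It stands to compound 3 exactly as compound 2 stands to compound 1: the change is a group of 3 heavy atoms (1 carbon, 2 nitrogen; no ring) in place of a hydrogen atom, on a sulfonamide nitrogen, and the place of the change is described in the same words in both pairs, so it is the same change applied to a second core. On the core of compound 1 this change produced only a 1.5-fold higher number from compound 1 to compound 2 (0.16 log units; within the scatter). For that reason the step expected here is a 1.3-fold higher number from compound 3 to compound 4 (0.13 log units; within the scatter), an estimate that rests on compound 3 having given 3.73 ug/mL and on the earlier pair staying within the scatter. Compound 4 is therefore expected to give about 5 ug/mL in this assay, with a likely range from 2.5 ug/mL to 10 ug/mL.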

Compound 4, half-maximal inhibitory concentration: 4.35 ug/mL
For compound 4 the middle estimate is 1.1-fold (0.06 log units) above the measured one, and the stated range covers the measured number.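

In this assay the new step is a 1.2-fold higher number from compound 3 to compound 4 (0.07 log units; within the scatter), and set beside the earlier step, the change behaves alike on the two cores: the same change on two cores in this assay, a 1.5-fold higher number (0.16 log units; within the scatter) from compound 1 to compound 2 and a 1.2-fold higher number (0.07 log units; within the scatter) from compound 3 to compound 4, 1.3-fold (0.10 log units) apart, within the scatter of two such steps. Within these two pairs, the group on the sulfonamide nitrogen could therefore be carried from the core of compound 1 to the core of compound 3 without any step beyond the scatter, and the small step on the first core was a fair guide to the step on the second. Going by these compounds alone, this does not show that the change would stay this small on every core, since the agreement rests on only two pairs in a single cell assay, and two steps this small cannot reveal any difference between the cores in how they respond to it.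

The compounds shown leave open whether other groups on the sulfonamide nitrogen, such as a methyl, an acetyl or a longer chain, would also leave the number in place. They also leave open what an amine or a carboxylic acid would do in place of the whole sulfonamide, and which part of the difference between the two cores accounts for the gap between their parent compounds.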